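A few compounds are considered here, and "the series" means these few. Any claim that something is new, unique, unknown or untested is made for them only; others in the source may bear on it.

Measured in a functional assay with Homo sapiens as the target; on this read-out higher numbers stand for weaker inhibition and lower numbers for stronger inhibition:
- compound 1 `CC(C)[C@H](NC(=O)COc1cccc2ccccc12)C(=O)N[C@@H](CC(=O)O)C(=O)COc1ccccc1`: 11200 nM
- compound 2 `CC(C)[C@H](NC(=O)COc1cccc2ccccc12)C(=O)N[C@@H](CC(=O)O)C(=O)COc1c(F)cccc1F`: > 100000 nM (a limit of the assay, not a number)
- compound 3 `CC(C)[C@H](NC(=O)COc1cccc2ccccc12)C(=O)N[C@@H](CC(=O)O)C(=O)COc1ccc(F)c(F)c1F`: 20600 nM

Among the measured compounds shown here, compound 3 and compound 1 hold the only two numbers, and these lie within the scatter of each other. The third entry is a limit.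

The next compound is compound 4 `CC(C)[C@H](NC(=O)COc1cccc2ccccc12)C(=O)N[C@@H](CC(=O)O)C(=O)COc1c(F)cc(F)cc1F`, and the change is 2,4,6-trifluorophenyl in place of 2,3,4-trifluorophenyl on an oxygen on a saturated carbon. In words, 2,4,6-trifluorophenyl stands in place of 2,3,4-trifluorophenyl on an oxygen on a saturated carbon.

For the measured compounds named here, three measured steps bear on this. a 1.8-fold higher number from compound 1 to compound 3 (0.26 log units; within the scatter) stays within the scatter. an at least 8.9-fold higher number from compound 1 to compound 2 (0.95 log units; beyond the scatter) and an at least 4.8-fold lower number from compound 2 to compound 3 (0.68 log units; beyond the scatter) both go beyond it, and both involve the 2,6-difluorophenyl group of compound 2. The name 2,4,6-trifluorophenyl keeps the 2 and 6 fluorines of that group, so compound 4 is expected to lie nearer compound 2 than compound 3, though this rests on compound 2 alone. A result reported only as a limit is a real possibility. A higher number is expected, with an estimated 2.9-fold higher number from compound 3 to compound 4 (0.46 log units; beyond the scatter). The estimated value for compound 4 is 60000 nM, with an expected range of 20000 nM to 150000 nM.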

Compound 4, half-maximal inhibitory concentration: 14900 nM
Estimate against measurement, compound 4: 4.0-fold (0.60 log units) above, outside the stated range (below it).
By their numbers in this assay, from the lowest: compounds 1, 4 and 3 (each within the scatter of the next). At a limit, above all of these: compound 2.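

In this assay, a 1.4-fold lower number from compound 3 to compound 4 (0.14 log units; within the scatter) and a 1.3-fold higher number from compound 1 to compound 4 (0.12 log units; within the scatter), so on an oxygen on a saturated carbon, 2,4,6-trifluorophenyl reads the same as 2,3,4-trifluorophenyl and phenyl. Keeping the fluorines of the 2,6-difluorophenyl group therefore does not by itself carry the result of that group, as fluoro in place of hydrogen on an aromatic carbon gives an at least 6.7-fold lower number from compound 2 to compound 4 (0.82 log units; beyond the scatter). Compound 2 holds a limit of the assay and not a number, and it now stands alone in this series: the limit of > 100000 nM in this assay, at which 1 of the 4 values shown sits.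

What separates compound 2 from compound 4 cannot be told from this one pair, since the series holds only a single 2,6-difluorophenyl example. Also open is how chloro or methoxy on the phenyl group would read at this position, as all substituents shown there are fluoro.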